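The compounds below may be only part of what the source reports. "The series", "measured", "known", "first", "only" and "open" are said of these compounds alone.

Measured so far:
- compound 1, `Nc1nc(N)c(CCCN(Cc2ccc(NC(CCC(=O)O)C(=O)O)cc2)c2cc(F)c(F)cc2[N+](=O)[O-])c(O)n1`: > 100000 nM
- compound 2, `Nc1nc(N)c(CCCN(Cc2ccc(NC(CCC(=O)O)C(=O)O)cc2)c2ccc([N+](=O)[O-])c(F)c2F)c(O)n1`: > 100000 nM
- compound 3, `CC(C)(C)OC(=O)CCC(Nc1ccc(CN(CCCc2c(N)nc(N)nc2O)c2ccc([N+](=O)[O-])c(F)c2F)cc1)C(=O)OC(C)(C)C`: 20000 nM

All three were tested in a functional assay on CCRF-CEM cells (Homo sapiens) for cytotoxicity, in the absence of a further agent; on this read-out higher numbers stand for weaker inhibition and lower numbers for stronger inhibition. For compound 1 the value > 100000 nM is a limit of the assay, not a number. For compound 2 the value > 100000 nM is likewise a limit. Compound 3 is the only one of the three with a real number, 20000 nM in this assay.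

Compound 1 and compound 2 differ in one place: 4,5-difluoro-2-nitrophenyl in place of 2,3-difluoro-4-nitrophenyl on an amine nitrogen. The resulting step, a step that the two limits leave unreadable from compound 2 to compound 1, cannot be sized because the limit of > 100000 nM in this assay, at which 2 of the 3 values shown sit, holds both of them. Compound 2 and compound 3 differ in more than one place, and the difference between their two cores is not broken down here.

Compound 4, `CC(C)(C)OC(=O)CCC(Nc1ccc(CN(CCCc2c(N)nc(N)nc2O)c2cc(F)c(F)cc2[N+](=O)[O-])cc1)C(=O)OC(C)(C)C`, has not yet been measured in this assay. It differs from compound 3 by the same change: 4,5-difluoro-2-nitrophenyl in place of 2,3-difluoro-4-nitrophenyl on an amine nitrogen. For the measured compounds named here, the only earlier example of this change, from compound 2 to compound 1, gives no readable size, so there is nothing that points to a large shift in either direction. The expectation is therefore that compound 4 will sit near compound 3, with a step of about a 1.3-fold higher number from compound 3 to compound 4 (0.10 log units; within the scatter), and the uncertainty is wide. Compound 4 is estimated at 25000 nM, expected to lie between 7000 nM and 100000 nM in this assay.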

Compound 4, half-maximal inhibitory concentration: 1700 nM
Compound 4: middle estimate off by 15-fold (1.17 log units), on the high side; the measured number lies below the stated range.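

In this assay, putting 4,5-difluoro-2-nitrophenyl in place of 2,3-difluoro-4-nitrophenyl on the amine nitrogen gives a 12-fold lower number from compound 3 to compound 4 (1.07 log units; beyond the scatter), so on the core of compound 3 the way the same atoms are joined within this group makes a large difference to the read-out. This is a single readable example on a single core, so it does not make a rule for the series, and it does not say why the number falls. Whether the step carries over to the core of compound 1 and compound 2 remains unknown, and the same change on that core cannot be sized for this reason: the limit of > 100000 nM in this assay, at which 2 of the 4 values shown sit.

The compounds shown leave open whether a step of this size would return with a nitrile in place of the nitro group, or with chlorine in place of the two fluorines on the same ring. They also leave open whether the core with ethyl esters in place of the tert-butyl esters of compound 3 and compound 4 would give two real numbers, and so a further readable example of this change.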